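Replacing the 5-aminopyridazin-3-yl group of compound 3

The source may hold more compounds than are shown below. What is called first, only, known or untested is meant among the compounds shown, and "the series" means these compounds.

Of the compounds shown here, three sharing one core have been measured in an in vitro ADME assay on microsomes from liver (Rattus norvegicus) for metabolic stability; a lower number here means slower removal, a higher number faster removal of the compound. In this assay compound 1 `Nc1cc(Nc2ccc(Oc3ccc(Cl)cc3)cc2)ncn1` gives 32 mL.min-1.g-1 and compound 2 `Nc1nccc(Nc2ccc(Oc3ccc(Cl)cc3)cc2)n1` gives 41 mL.min-1.g-1. The difference between these two is small: a 1.3-fold higher number from compound 1 to compound 2 (0.11 log units; within the scatter).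

Compound 3 `Nc1cnnc(Nc2ccc(Oc3ccc(Cl)cc3)cc2)c1` gives > 399 mL.min-1.g-1, which is a limit of the assay and not a number. Compound 3 therefore stands at the limit of > 399 mL.min-1.g-1 in this assay, at which 1 of the 3 values shown sits. The two measured steps leading to it are large: an at least 12-fold higher number from compound 1 to compound 3 (1.09 log units; beyond the scatter), and an at least 9.7-fold higher number from compound 2 to compound 3 (0.98 log units; beyond the scatter).

Compound 4 `Nc1nsc(Nc2ccc(Oc3ccc(Cl)cc3)cc2)n1` has not been measured yet. It carries 3-amino-1,2,4-thiadiazol-5-yl in place of 5-aminopyridazin-3-yl, on a nitrogen on an aromatic ring: 3-amino-1,2,4-thiadiazol-5-yl in place of 5-aminopyridazin-3-yl on a nitrogen on an aromatic ring.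

For the measured compounds named here, no measured step brings in this new group, so the evidence is indirect. The steps do show that the group at this place can matter a great deal. The group now leaving is the one that gave an at least 9.7-fold higher number from compound 2 to compound 3 (0.98 log units; beyond the scatter), so a clear move towards lower numbers is expected, with wide uncertainty. The expected step is an at least 4.4-fold lower number from compound 3 to compound 4 (0.64 log units; beyond the scatter). For compound 4 the estimate is 90 mL.min-1.g-1, with an expected range from 25 mL.min-1.g-1 to 350 mL.min-1.g-1.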

Compound 4, intrinsic clearance in microsomes: < 14 mL.min-1.g-1
Compound 4: a limit, no number; the forecaster's own chance of this, stated with the estimate: 15%; middle value at least 6.4-fold (0.80 log units) away from the limit.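

In this assay, compound 4 stands at a limit of the assay and not at a number: the limit of < 14 mL.min-1.g-1 in this assay, at which 1 of the 4 values shown sits.

For the compounds shown here, the earlier compounds showed only that a change of group at this place, on a nitrogen on an aromatic ring, could send the number sharply upwards, and the replacement of 5-aminopyridazin-3-yl by 3-amino-1,2,4-thiadiazol-5-yl now gives a large move the other way, with an at least 28-fold lower number from compound 3 to compound 4 (1.45 log units; beyond the scatter), a step whose two ends are both limits of the assay. The five-membered ring also goes beyond the two six-membered aminopyrimidine groups, which could not be told apart from each other, with an at least 2.9-fold lower number from compound 2 to compound 4 (0.46 log units; beyond the scatter) and an at least 2.2-fold lower number from compound 1 to compound 4 (0.35 log units; beyond the scatter), so this position can move the number in both directions.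

The compounds shown do not separate the effect of the sulfur from that of the ring size, since the entering group changes both at once. They also leave open where an aminooxadiazole, with oxygen in place of the sulfur, or a thiadiazole carrying a methylamine in place of the amine would fall in this assay.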